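The source may hold more compounds than are shown below. What is called first, only, known or untested is meant among the compounds shown, and "the series" means these compounds.

Measured so far in a functional assay on HepG2 cells (Homo sapiens) for cytotoxicity, read by MTT assay, with a stated time of 96 h; a higher number here means that more compound is needed for the effect, a lower number that less compound is needed:
compound 1 `COc1ccc(-c2[nH]c3ccccc3c2/C=C(\C#N)S(=O)(=O)c2ccccc2)cc1` gives 11000 nM;
compound 2 `COc1ccc(-c2[nH]c3ccc(OC)cc3c2/C=C(\C#N)S(=O)(=O)c2ccccc2)cc1` gives 6400 nM;
compound 3 `CCOC(=O)/C(=C/c1c(-c2ccccc2)[nH]c2ccccc12)C(=O)c1ccc([N+](=O)[O-])cc1` gives 28000 nM.

Compound 2 shows the lowest of the three numbers, yet compound 1 sits within the scatter of it: the step of a 1.7-fold lower number from compound 1 to compound 2 (0.24 log units; within the scatter) is too small to count as a real change. Only compound 3, which is built on a different core, stands clearly apart, with a gap beyond the scatter.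

Compound 4 `COc1ccc2[nH]c(-c3ccccc3)c(/C=C(\C#N)S(=O)(=O)c3ccccc3)c2c1` is not yet measured. It differs from compound 2 by hydrogen in place of methoxy on an aromatic carbon; cut one bond further out, the change reads 4-methoxyphenyl to phenyl. Among the compounds with values here, the only measured single step, from compound 1 to compound 2, concerns a methoxy on another aromatic ring of the shared core and stayed within the scatter; no measured step touches the 4-methoxyphenyl group itself. Because a 1.7-fold lower number from compound 1 to compound 2 (0.24 log units; within the scatter) was small, a methoxy elsewhere serves only as a rough guide, and the expectation is a step of a 1.3-fold higher number from compound 2 to compound 4 (0.10 log units; within the scatter) that stays within the scatter. Compound 4 is estimated at 8000 nM, with a range from 3500 nM to 20000 nM.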

Compound 4, half-maximal effective concentration: 9600 nM
Compound 4: middle estimate off by 1.2-fold (0.08 log units), on the low side; low and high end bracket the measured number.
By their numbers in this assay, from the lowest: compounds 2, 4 and 1 (each within the scatter of the next); then compound 3.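

Among the compounds shown, this is the only step at this position: hydrogen replaces the methoxy, turning 4-methoxyphenyl into phenyl, and in this assay it gives a 1.5-fold higher number from compound 2 to compound 4 (0.18 log units; within the scatter). The methoxy here therefore makes no difference that this assay can resolve, and the same holds for the methoxy on the other aromatic ring of the shared core, with a 1.7-fold lower number from compound 1 to compound 2 (0.24 log units; within the scatter). No measurement of any underlying property accompanies these results to explain the size of the step.

At this position the compounds shown offer only hydrogen and methoxy, so it stays open whether an amine, a carboxylic acid or a longer chain would move the number beyond the scatter. Also open, from the compounds shown here alone, is what a compound carrying neither methoxy would give.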